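The source may hold more compounds than are shown below. What is called first, only, known or untested is meant among the compounds shown, and "the series" means these compounds.

In a functional assay (Mus musculus) for inhibition, with a stated time of 5 days (a higher number here means a weaker inhibitor, a lower number a stronger inhibitor), compound 1 `O=Cc1cn(-c2ccc(O)cc2)nc1-c1ccc(O)c(O)c1` gives 12000 nM and compound 2 `CCOC(=O)/C=C/c1cn(-c2ccc(O)cc2)nc1-c1ccc(O)c(O)c1` gives 6200 nM, two values within the scatter of each other. Compound 3 `CCOC(=O)/C=C/c1cn(-c2ccc(O)cc2)nc1-c1ccccc1` has phenyl in place of 3,4-dihydroxyphenyl on an aromatic carbon of compound 2: phenyl in place of 3,4-dihydroxyphenyl on an aromatic carbon. For the measured compounds named here, the only measured step, a 1.9-fold lower number from compound 1 to compound 2 (0.29 log units; within the scatter), lies at another place and within the scatter, so it gives no size for this change. Going by the values given here, with no measured step at this place, only a small, uncertain move toward a higher number is expected, a 1.8-fold higher number from compound 2 to compound 3 (0.25 log units; within the scatter). For compound 3 the estimated value is 11000 nM, with an expected range of 3500 nM to 35000 nM.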

Compound 3, half-maximal inhibitory concentration: 29000 nM
Compound 3: middle estimate off by 2.6-fold (0.42 log units), on the low side, and the stated range covers the measured number.
By their numbers in this assay, from the lowest: compounds 2 and 1 (each within the scatter of the next); then compound 3.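

For the compounds shown here, at this place, next to the ring nitrogen, phenyl in place of 3,4-dihydroxyphenyl gives the first step beyond the scatter in this assay, a 4.7-fold higher number from compound 2 to compound 3 (0.67 log units; beyond the scatter). The hydroxyl groups of 3,4-dihydroxyphenyl therefore count for something here, whereas the formyl change elsewhere on the ring stayed within the scatter. No measured evidence says why the number rises. From the compounds shown here alone, whether either hydroxyl group alone carries the difference stays open. So does what a methoxy group or an amine on this phenyl would do in their place.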